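This account rests on a few compounds, and the source may have more. Where it says the series, first, only, none or still open, it means among the compounds named here.

Measured compounds:
- compound 1 `CCN(c1cccc(-c2ccccc2)c1)c1ccc(C#N)c(Cl)c1` — "not determined" (no result reported) in an ADME assay on L02 cells (Homo sapiens) for antiproliferative activity, read by CCK-8 assay, with a stated time of 6 days; on this read-out lower numbers stand for stronger inhibition and higher numbers for weaker inhibition
- compound 2 `N#Cc1ccc(N2CCCc3c(-c4ccncc4)cccc32)cc1C(F)(F)F` — 6380 nM in this assay
- compound 3 `CCN(c1ccc(C#N)c(Cl)c1)c1cc(-c2cn[nH]c2)ccc1C` — "not determined" (no result reported) in this assay

Compound 3 stands without a number in this assay; compound 1 is in the same position, so the only figure the series offers is that of compound 2, which gives 6380 nM in this assay. Nothing can therefore be said of where compound 3 sits relative to the others on this read-out.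

Compound 4 `CCN(c1ccc(C#N)c(Cl)c1)c1cc(-c2ccnn2C)ccc1C` is the next compound to be measured in this assay. It differs from compound 3 in one place: 1-methyl-1H-pyrazol-5-yl in place of 1H-pyrazol-4-yl on an aromatic carbon. Among the compounds with values here, with no number for compound 3 and no step between measured compounds, there is no basis for expecting a shift in this assay in either direction beyond the scatter; the expectation for compound 4 must rest on the single figure of compound 2 alone. Compound 4 is thus expected to give about 6000 nM in this assay, with a wide range from 1500 nM to 25000 nM.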

Compound 4, half-maximal inhibitory concentration: 6230 nM
The estimate for compound 4 lay 1.0-fold (0.02 log units) below the measured number; the measured number falls inside the stated range.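

No step can be read from compound 3 to compound 4: in this assay compound 3 has no single number, so compound 4 at 6230 nM has nothing to be set against. The compounds shown leave open what replacing 1H-pyrazol-4-yl with 1-methyl-1H-pyrazol-5-yl does on this read-out. No evidence bears on this result.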